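From methoxy to hydroxy on one end group

This account rests on a few compounds, and the source may have more. Where it says the series, first, only, none or still open, it means among the compounds named here.

Compound 1 `COc1ccc(/C=C2\CCC/C(=C\c3ccccc3Cl)C2=O)cc1OC` and compound 2 `COc1cccc(/C=C2\CCC/C(=C\c3ccc(OC)c(OC)c3)C2=O)c1` share a core and differ in one end group. In a functional assay on A549 cells (Homo sapiens) for cytotoxicity, read by MTT assay, with a stated time of 72 h (a higher number here means a weaker inhibitor, a lower number a stronger inhibitor), compound 1 gives > 20000 nM, which is a limit of the assay and not a number. For the measured compounds named here, in the same test, compound 2 gives 6700 nM, so it holds the only true number so far and has nothing measured on its stronger side.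

Compound 3 `COc1ccc(/C=C2\CCC/C(=C\c3cccc(O)c3)C2=O)cc1OC` alters that same end group of compound 2: hydrogen in place of methyl on an oxygen on an aromatic ring. Here hydrogen takes the place of methyl on an oxygen on an aromatic ring, turning 3-methoxyphenyl into 3-hydroxyphenyl.

Going by the values given here, only one measured step bears on this. Putting 3-methoxyphenyl in place of 2-chlorophenyl gave an at least 2.9-fold lower number from compound 1 to compound 2 (0.47 log units; beyond the scatter), which shows that this group can move the result. That step replaced a whole different group, however, and one end of it is only a limit, so it gives no size or direction for losing a methyl. No step beyond the scatter is therefore expected in this assay, though the uncertainty is wide. The expected change is a 1.3-fold lower number from compound 2 to compound 3 (0.13 log units; within the scatter). Compound 3 is estimated at 5000 nM, with an expected range of 1800 nM to 15000 nM.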

Compound 3, half-maximal inhibitory concentration: 4300 nM
The estimate for compound 3 lay 1.2-fold (0.07 log units) above the measured number; the measured number falls inside the stated range.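

In this assay, hydrogen in place of methyl on an oxygen on an aromatic ring gives a 1.6-fold lower number from compound 2 to compound 3 (0.19 log units; within the scatter), so 3-methoxyphenyl and 3-hydroxyphenyl cannot be told apart in this test, and the methyl on that oxygen makes no difference that can be read here. The other new step, an at least 4.6-fold lower number from compound 1 to compound 3 (0.66 log units; beyond the scatter), lies beyond the scatter, which means that 3-hydroxyphenyl, like 3-methoxyphenyl, reads differently from 2-chlorophenyl at this end group, so the earlier gap does not depend on that methyl. The true size of this step stays open, because the value of compound 1 is a limit of the assay and not a number: the limit of > 20000 nM in this assay, at which 1 of the 3 values shown sits.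

The compounds shown do not tell whether the oxygen itself matters, and a 3-aminophenyl group or a plain phenyl group in the same place would speak to that. On these data alone, it also remains open how a carboxylic acid or a longer chain on that oxygen, such as ethoxy, would read in this assay, and whether the likeness of methoxy and hydroxy holds on the other end group of the shared core.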